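The source may report more compounds than this note shows. Statements on the series, on what has been measured and on what is new or still open speak of the compounds shown alone.

Compound 2 `FC(F)(F)c1ccc2[nH]c(-c3ccc(-c4nnc[nH]4)cc3)nc2c1` gives 3080 nM in a functional assay for antagonist activity at Neuropeptides B/W receptor type 1 (Homo sapiens), read by cAMP accumulation (on this read-out lower numbers stand for stronger inhibition and higher numbers for weaker inhibition), the highest of the two numbers recorded here. Its nearest neighbour is compound 1 `FC(F)(F)c1ccc2[nH]c(-c3ccccc3)nc2c1`, which in this assay gives 1200 nM; the step of a 2.6-fold higher number from compound 1 to compound 2 (0.41 log units; beyond the scatter) is modest but beyond the scatter. Compound 3 `NCc1ccc(-c2ccc(-c3nc4cc(C(F)(F)F)ccc4[nH]3)cc2)cc1` differs from compound 2 by 4-(aminomethyl)phenyl in place of 4H-1,2,4-triazol-3-yl on an aromatic carbon. Among the compounds with values here, no measured pair covers this exchange directly; the only step touching that aromatic carbon is a 2.6-fold higher number from compound 1 to compound 2 (0.41 log units; beyond the scatter), which shows what a five-membered aromatic ring did there relative to hydrogen, not what the larger six-membered group of compound 3 would do. On that thin basis the step of a 1.2-fold lower number from compound 2 to compound 3 (0.09 log units; within the scatter) is expected to remain small, with no clear direction and wide uncertainty. Compound 3 is therefore estimated at 2500 nM in this assay, with a range from 600 nM to 10000 nM.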

Compound 3, half-maximal inhibitory concentration: 720 nM
The estimate for compound 3 lay 3.5-fold (0.54 log units) above the measured number, and the stated range covers the measured number.
By their numbers in this assay, from the lowest: compounds 3 and 1 (each within the scatter of the next); then compound 2.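

In this assay, the result shows that the group on this aromatic carbon decides the outcome, and that size alone does not impose a penalty there: the larger 4-(aminomethyl)phenyl gives a 4.3-fold lower number from compound 2 to compound 3 (0.63 log units; beyond the scatter). Measured against hydrogen, the same group gives a 1.7-fold lower number from compound 1 to compound 3 (0.22 log units; within the scatter), so this carbon accepts 4-(aminomethyl)phenyl with no change beyond the scatter, while the earlier compounds had shown only a loss on substitution. No measurement given here explains the difference between the two groups.

The compounds shown leave open whether the amine of the aminomethyl group or the added carbon-only ring separates compound 3 from compound 2. A plain phenyl or a 4-(hydroxymethyl)phenyl on this carbon would address that, and would also test whether any group here can improve on hydrogen.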